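A few compounds are considered here, and "the series" means these few. Any claim that something is new, unique, unknown or untested is made for them only; others in the source may bear on it.

Compound 1 `O=C(Nc1ccccc1)c1ccc(CO[N+](=O)[O-])cc1`: 800 nM
Compound 2 `O=C(Nc1ccccc1)c1cccc(CO[N+](=O)[O-])c1`: 8400 nM

In a functional assay on MDA-MB-231 cells (Homo sapiens) for antiproliferative activity, read by CCK-8 assay and cell counting, with a stated time of 72 h (a lower number here means a stronger inhibitor, a higher number a weaker inhibitor), compound 1 gives 800 nM. Among the measured compounds shown here, this is the lower of the two numbers so far, and the gap to compound 2 at 8400 nM lies beyond the usual scatter. Compound 1 is therefore the reference point for the next comparison.

Compound 3 `CCc1ccc(C(=O)Nc2ccccc2)cc1` keeps the core of compound 1 but has methyl in place of nitrooxy on a saturated chain carbon bound to an aromatic carbon, so that (nitrooxy)methyl becomes ethyl: methyl in place of nitrooxy on a saturated chain carbon bound to an aromatic carbon. For the measured compounds named here, both measured compounds carry nitrooxy, so the data contain no direct precedent for removing it, and any expectation here is tentative. Going by the values given here, the values of compound 1 at 800 nM and compound 2 at 8400 nM show only that numbers in this small set can differ widely between close structures.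

A weaker result in this assay is expected, with a higher number and a change beyond the scatter: the expected step is a 25-fold higher number from compound 1 to compound 3 (1.40 log units; beyond the scatter). For compound 3 the estimated value is 20000 nM, with an expected range of 5000 nM to 80000 nM.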

Compound 3, half-maximal inhibitory concentration: > 100000 nM
Compound 3: a limit, no number; the forecaster's own chance of this, stated with the estimate: 35%; middle value at least 5.0-fold (0.69 log units) away from the limit.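

In this assay compound 3 gives > 100000 nM, and this reading is a limit of the assay, not a number: the limit of > 100000 nM in this assay, at which 1 of the 3 values shown sits.

The exchange of nitrooxy for methyl on a saturated chain carbon bound to an aromatic carbon, which turns (nitrooxy)methyl into ethyl, gives an at least 120-fold higher number from compound 1 to compound 3 (2.09 log units; beyond the scatter), a large step well beyond the scatter. Among the compounds shown here, both earlier compounds carry nitrooxy, so only this pair tests its removal, and it shows that, with the rest of the core of compound 1 unchanged, the antiproliferative reading depends strongly on what occupies this place; the size of the step is bounded on one side only, so it may be larger still.

A single exchange leaves open whether nitrooxy itself is required or whether another group at this place, such as a hydroxyl, a methoxy or an amine on the same chain carbon, would hold the value of compound 1. Also open, going by these compounds, is whether the same exchange on compound 2 would give a step of similar size, and the pair offers no measured basis for a cause of the step.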